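This account rests on a few compounds, and the source may have more. Where it says the series, first, only, none or still open, it means among the compounds named here.

Of the compounds shown here, three of one shared core have been tested so far. Compound 1 `C[C@H]1[C@H](NCc2ccc(Cl)s2)C[C@H]2C[C@@H]1C2(C)C` gives 25000 nM in an ADME assay on MDCK cells (Canis lupus familiaris) for cytotoxicity, read by microscopy, with a stated time of 48 h; on this read-out lower numbers stand for higher toxicity in this test and higher numbers for lower toxicity in this test. Compound 2 `C=Cc1ccsc1CN[C@@H]1C[C@H]2C[C@@H]([C@H]1C)C2(C)C` gives 50000 nM in this assay, and compound 3 `C[C@H]1[C@H](NCc2cc(C3CC3)cs2)C[C@H]2C[C@@H]1C2(C)C` gives 25000 nM in this assay. Compound 3 thus stands level with compound 1 at the digits shown, and the number of compound 2 lies within the scatter of both, so the three results are not distinguishable from one another in this test.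

Compound 4 `CCCCc1csc(CN[C@@H]2C[C@H]3C[C@@H]([C@H]2C)C3(C)C)c1` has not yet been measured. It differs from compound 3 in one place: butyl in place of cyclopropyl on an aromatic carbon. Within the data shown here, nothing among the measured compounds shows how a change of this kind affects this assay, as no pair of them differs in one place. The three results so far are all alike, and the change is a small one on the ring. Compound 4 is therefore expected to show a step of no change at the digits printed from compound 3 to compound 4 (within the scatter), that is, no shift beyond the scatter. The estimate for compound 4 is 25000 nM, with a range from 12500 nM to 50000 nM.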

Compound 4, minimum cytotoxic concentration: 12500 nM
The estimate for compound 4 lay 2.0-fold (0.30 log units) above the measured number; measured number inside the range.
By their numbers in this assay, from the lowest: compounds 4, 1, 3 and 2 (each within the scatter of the next, the first and the last beyond it).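

Among these compounds, this is the first pair of compounds that differ in one place, so it gives the first direct reading of a change at this position. In this assay, replacing cyclopropyl with butyl on an aromatic carbon, two ring bonds from the ring sulfur, gives a 2.0-fold lower number from compound 3 to compound 4 (0.30 log units; within the scatter), so this test does not tell the open chain from the small carbon ring at this place. No measurement on hand offers a reason for this result.

Among the compounds shown here, both groups in this pair contain only carbon and neither has a hydrogen-bond donor or acceptor, so the reading covers only that kind of group. On these data alone, how an amine or a carboxylic acid at this place, or a chain longer than butyl, would read in this assay remains open.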